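Saturated ring amine exchange: compound 3 to compound 4

The source may report more compounds than this note shows. Statements on the series, on what has been measured and on what is new or still open speak of the compounds shown alone.

Within the data shown here, compound 3 `CC(C(=O)NCc1ccc(C(F)(F)F)nc1N1CCCCCCC1)c1ccc(NS(C)(=O)=O)c(F)c1` gives 0.7 nM in a functional assay on CHO-K1 cells for antagonist activity at transient receptor potential cation channel subfamily V member 1 (Homo sapiens), read by FLIPR (a higher number here means a weaker inhibitor, a lower number a stronger inhibitor), the lowest of the three numbers so far. Compound 1 `CC(C(=O)NCc1ccc(C(F)(F)F)nc1Nc1ccccc1)c1ccc(NS(C)(=O)=O)c(F)c1` gives 59.6 nM and compound 2 `CC(C(=O)NCc1ccc(C(F)(F)F)nc1N1CCC(CN(C)C)CC1)c1ccc(NS(C)(=O)=O)c(F)c1` gives 2.1 nM; the steps of an 85-fold lower number from compound 1 to compound 3 (1.93 log units; beyond the scatter) and a 3.0-fold lower number from compound 2 to compound 3 (0.48 log units; beyond the scatter) place compound 3 clearly ahead. Compound 4 `CC(C(=O)NCc1ccc(C(F)(F)F)nc1N1CCN(C)CC1)c1ccc(NS(C)(=O)=O)c(F)c1` carries a group of 7 heavy atoms (5 carbon, 2 nitrogen; one six-membered non-aromatic ring with 2 hetero atoms) in place of a group of 8 heavy atoms (7 carbon, 1 nitrogen; one eight-membered non-aromatic ring with 1 hetero atom), on an aromatic carbon. The step bearing most directly on this change is a 3.0-fold lower number from compound 2 to compound 3 (0.48 log units; beyond the scatter), a modest one between two saturated ring amines, whereas an 85-fold lower number from compound 1 to compound 3 (1.93 log units; beyond the scatter) is large. Because a 3.0-fold lower number from compound 2 to compound 3 (0.48 log units; beyond the scatter) was only modest, compound 4 is expected to move back by a comparable amount, a 4.3-fold higher number from compound 3 to compound 4 (0.63 log units; beyond the scatter). The estimate for compound 4 is 3 nM, with a range from 1 nM to 10 nM.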

Compound 4, inhibition constant: 146 nM
Estimate against measurement, compound 4: 49-fold (1.69 log units) below, outside the stated range (above it).
By their numbers in this assay, from the lowest: compound 3; then compound 2; then compound 1; then compound 4.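

In this assay, a saturated ring amine at this position does not by itself give a low number: a 210-fold higher number from compound 3 to compound 4 (2.32 log units; beyond the scatter) and a 70-fold higher number from compound 2 to compound 4 (1.84 log units; beyond the scatter) set 4-methylpiperazin-1-yl far behind the other two saturated ring amines. With a 2.4-fold higher number from compound 1 to compound 4 (0.39 log units; beyond the scatter), compound 4 also falls behind the anilino compound, so it goes against the order that compound 2 and compound 3 suggested. No measurement shown accounts for this gap.

Ring size and the second ring nitrogen change together in this step, so their shares remain unseparated. A piperidin-1-yl or morpholin-4-yl group at the same place would help to separate them.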